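This account rests on a few compounds, and the source may have more. Where it says the series, first, only, none or still open, it means among the compounds named here.

Compound 1 `CN(C(=O)NC(=O)c1c(F)cccc1F)c1nc(C(F)(F)F)c(C(=O)N/N=C/c2cccc(C(F)(F)F)c2)s1` gives 27.6 ug/mL in a functional assay on A549 cells (Homo sapiens) for inhibition, read by MTT assay, with a stated time of 72 h; on this read-out lower numbers stand for stronger inhibition and higher numbers for weaker inhibition.
Compound 2 `CN(C(=O)NC(=O)c1cccc(C(F)(F)F)c1)c1nc(C(F)(F)F)c(C(=O)N/N=C/c2cc(C(F)(F)F)cc(C(F)(F)F)c2)s1` gives 8.2 ug/mL in this assay.
Compound 3 `CN(C(=O)NC(=O)c1ccccc1F)c1nc(C(F)(F)F)c(C(=O)N/N=C/c2cccc(C(F)(F)F)c2)s1` gives 19.5 ug/mL in this assay.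

Among these three numbers compound 3 stands second highest: its nearest neighbour is compound 1, and the only single-point step that is known, a 1.4-fold lower number from compound 1 to compound 3 (0.15 log units; within the scatter), stays within the scatter. Compound 2 gives the lowest number, but it differs from compound 3 in two places at once, so no single step can be read from it.

Compound 4 `CN(C(=O)NC(=O)c1cccc(C(F)(F)F)c1)c1nc(C(F)(F)F)c(C(=O)N/N=C/c2cccc(C(F)(F)F)c2)s1` is reached from compound 3 by 3-(trifluoromethyl)phenyl in place of 2-fluorophenyl on a carbonyl carbon. Among the compounds with values here, no measured pair isolates this change. The only thing that speaks to it is compound 2, which carries the same 3-(trifluoromethyl)phenyl group on its carbonyl carbon together with a second change elsewhere, and gives 8.2 ug/mL. With that as the only hint, a modest move toward a lower number is expected, a 1.5-fold lower number from compound 3 to compound 4 (0.18 log units; within the scatter), though a result within the scatter would not be surprising. Compound 4 is therefore estimated at 13 ug/mL, with a range from 6 ug/mL to 30 ug/mL.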

Compound 4, half-maximal inhibitory concentration: 8.16 ug/mL
Beside the measured number, compound 4's estimate is 1.6-fold (0.20 log units) above it; the measured number falls inside the stated range.
By their numbers in this assay, from the lowest: compounds 4 and 2 (each within the scatter of the next); then compounds 3 and 1 (each within the scatter of the next).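

In this assay, within the data shown here, 3-(trifluoromethyl)phenyl on the carbonyl carbon gives the first single-change steps at this position that lie beyond the scatter: a 2.4-fold lower number from compound 3 to compound 4 (0.38 log units; beyond the scatter), measured against 2-fluorophenyl, and a 3.4-fold lower number from compound 1 to compound 4 (0.53 log units; beyond the scatter), measured against 2,6-difluorophenyl. The low number of compound 2 can now be read more clearly, since hydrogen in place of trifluoromethyl on an aromatic carbon leaves the result within the scatter, a 1.0-fold lower number from compound 2 to compound 4 (0.00 log units; within the scatter), so that second trifluoromethyl group shows no measurable effect here. No measurement shown here explains these steps.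

Among these compounds, only three fluorine-bearing aromatic groups on this carbonyl carbon can be compared so far. As far as these compounds go, whether an unsubstituted phenyl, or a phenyl carrying a methoxy group or an amine, would give a number like that of compound 4 remains open.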